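Fluoro for Cyano on a Bridged Amine Core

The compounds below may be only part of what the source reports. "The series", "measured", "known", "first", "only" and "open" are said of these compounds alone.

Compound 2 `N#Cc1ccc2c(c1)C1CNCC2C1` serves as the reference point. In an assay on HEK293 cells for binding affinity to Neuronal acetylcholine receptor; alpha4/beta2 (Homo sapiens) (a lower number here means a stronger inhibitor, a higher number a weaker inhibitor), compound 2 gives 0.5 nM, the lowest of the two numbers recorded. Its nearest neighbour among those numbers is compound 3 `c1ccc(-c2cccc3c2C2CNCC3C2)cc1`, which in this assay gives 1600 nM, a gap far beyond the scatter of repeated measurement. Compound 1 `Cc1nc2cc3c(cc2n1-c1ccccc1)C1CNCC3C1` is recorded in this assay only as a limit, < 5 nM, and not as a number, as noted in the limit of < 5 nM in this assay, at which 1 of the 3 values shown sits. Among the compounds with values here, no two of the measured compounds differ in a single place, so no measured step connects them, and the comparison of compound 2 with compound 3 shows only how widely the numbers spread.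

Compound 4 `Fc1ccc2c(c1)C1CNCC2C1` differs from compound 2 in one place: fluoro in place of cyano on an aromatic carbon. The nitrile, with its one hydrogen-bond acceptor, gives way to a single fluorine atom, and no ring is touched.

Within the data shown here, since no measured step covers this exchange, the expectation rests on compound 2 and its value of 0.5 nM in this assay. The step in this assay is expected to be a 4.0-fold higher number from compound 2 to compound 4 (0.60 log units; beyond the scatter), a modest weakening near the edge of the scatter. Compound 4 is estimated in this assay at 2 nM, within a range from 0.4 nM to 10 nM.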

Compound 4, inhibition constant: 1.1 nM
The estimate for compound 4 lay 1.8-fold (0.26 log units) above the measured number, and the stated range covers the measured number.
By their numbers in this assay, from the lowest: compound 2; then compound 4; then compound 3.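

In this assay, within the data shown here, fluoro in place of cyano on an aromatic carbon gives a 2.2-fold higher number from compound 2 to compound 4 (0.34 log units; beyond the scatter), and this is the first measured step, so two compounds can now be read against each other at a single place. The nitrile is not required at this aromatic carbon, meta to a fused ring and para to a fused ring, for a number close to that of the reference: with the triple bond and the hydrogen-bond acceptor of the cyano group gone and a single fluorine atom in their place, the step stays modest, though it lies beyond the scatter. Nothing measured among these compounds bears on why the step has this size.

The compounds shown leave open how a chloro group, a methoxy group or an amine on this aromatic carbon would compare with fluoro and cyano in this assay. They also leave open whether the same exchange would give a step of similar size on the core of compound 1 or of compound 3.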